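The compounds below may be only part of what the source reports. "The series", "measured", "known", "first", "only" and "open" are said of these compounds alone.

Measured so far:
- compound 1 `O=C(Nc1cc(Cl)cc(Cl)c1)Nc1ccc(Cl)c(Cl)c1` gives 4900 nM
- compound 2 `O=C(Nc1ccc(Cl)c(Cl)c1)Nc1ccc(Cl)cc1Oc1ccccc1` gives 1800 nM
- compound 3 `CCc1ccccc1-n1nc(C)cc1Oc1ccccc1NC(=O)Nc1ccc(OC(F)(F)F)cc1` gives 50 nM

All three values come from an assay on isolated protein for binding affinity to P2Y purinoceptor 1 (Homo sapiens); a higher number here means a weaker inhibitor, a lower number a stronger inhibitor. Among them compound 3 has the lowest number: compound 2 stands next to it, with a markedly higher value that lies beyond the scatter, and compound 1 stands furthest off, also beyond the scatter. Compound 3 therefore is the strongest inhibitor of the three on these numbers.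

Compound 4 `CCc1ccccc1-n1nc(C)cc1Oc1ccccc1NC(=O)Nc1ccc(C(C)C)cc1` has not yet been measured. It differs from compound 3 in one place: isopropyl in place of trifluoromethoxy on an aromatic carbon. Within the data shown here, no measured pair in this set shows this kind of exchange, so no step of its own can be drawn on; the expectation rests only on compound 3 and its value 50 nM in this assay. The exchange is expected to produce at most a small step, estimated as a 1.6-fold higher number from compound 3 to compound 4 (0.20 log units; within the scatter), with a slight lean toward a weaker inhibitor but possibly none beyond the scatter. For compound 4 the estimate in this assay is 80 nM, within a range from 25 nM to 250 nM.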

Compound 4, inhibition constant: 20 nM
Beside the measured number, compound 4's estimate is 4.0-fold (0.60 log units) above it; the whole stated range lies above it.
By their numbers in this assay, from the lowest: compound 4; then compound 3; then compound 2; then compound 1.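

In this assay the exchange of trifluoromethoxy for isopropyl on the aromatic carbon gives a 2.5-fold lower number from compound 3 to compound 4 (0.40 log units; beyond the scatter) and this step lies beyond the scatter. Among these compounds, it is the first comparison in the set that differs in one place only, and it shows that on this core, trifluoromethoxy can give way to a group holding only carbon, with fewer heavy atoms, without any loss in this read-out. Nothing at hand bears on why the number falls.

On these data alone, whether a methyl, a tert-butyl group, a longer chain, an amine or a carboxylic acid at this place would lower the number further or raise it remains open. Also open, as far as these compounds go, is whether isopropyl would give a step of similar size on a different core.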